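A few compounds are considered here, and "the series" means these few. Any claim that something is new, unique, unknown or untested is made for them only; others in the source may bear on it.

Values so far in a functional assay on NCI-H460 cells (Homo sapiens) for inhibition, read by sulforhodamine B assay, with a stated time of 72 h (a higher number here means a weaker inhibitor, a lower number a stronger inhibitor), as follows
compound 1 `CCNC(=O)c1nnn(-c2cc(C(C)C)c(O)cc2O)c1-c1ccc(CN2CCC[C@H](O)C2)cc1` gives 70 nM
compound 2 `CCNC(=O)c1nnn(-c2cc(C(C)C)c(O)cc2O)c1-c1ccc(CN2CCCC2)cc1` gives 3 nM

Compound 2 holds the lower of the two numbers. Compound 3 `CCNC(=O)c1nnn(-c2cc(C(C)C)c(O)cc2O)c1-c1ccc(CN(CC)CC)cc1` departs from compound 2 as follows: diethylamino in place of pyrrolidin-1-yl on a saturated chain carbon bound to an aromatic carbon. Within the data shown here, one measured step bears on this place: a 23-fold lower number from compound 1 to compound 2 (1.37 log units; beyond the scatter) (large). The number can therefore move far here, yet that step involved 3-hydroxypiperidin-1-yl, not diethylamino. A small rise, possibly within the scatter, is expected in this assay as the estimated step: a 1.7-fold higher number from compound 2 to compound 3 (0.22 log units; within the scatter) (expected). For compound 3 the estimate is 5 nM with 1.5 nM to 20 nM as the expected range.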

Compound 3, half-maximal inhibitory concentration: 11 nM
The estimate for compound 3 lay 2.2-fold (0.34 log units) below the measured number; the range from low to high includes it.
By their numbers in this assay, from the lowest: compound 2; then compound 3; then compound 1.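

In this assay, diethylamino does not stand in for pyrrolidin-1-yl on this saturated chain carbon: despite the same count of heavy atoms, the version without a ring gives a higher number (a 3.7-fold higher number from compound 2 to compound 3 (0.56 log units; beyond the scatter)). Diethylamino still gives a clearly lower number than 3-hydroxypiperidin-1-yl (a 6.4-fold lower number from compound 1 to compound 3 (0.80 log units; beyond the scatter)), so the order at this place runs compound 2, compound 3, compound 1.

Going by these compounds, whether morpholin-4-yl, piperazin-1-yl or a primary amine at the same place would hold the number of compound 2 remains open. Nothing at hand accounts for the gap between the ring and the open-chain amine.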